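Aryl variation on the shared urea-bearing core

The compounds below may be only part of what the source reports. "The series", "measured", "known", "first", "only" and "open" are said of these compounds alone.

Measured so far:
compound 1, `CCc1ccc(Nc2cc(NC(=O)Nc3c(Cl)cccc3Cl)ncn2)cc1`: 58%
compound 2, `COc1ccc(OC)c(Nc2cc(NC(=O)Nc3c(Cl)cccc3Cl)ncn2)c1`: 94.1%

In a functional assay on HCC827 cells (Homo sapiens) for inhibition, read by MTT assay, with a stated time of 48 h, tested at 10 uM (a higher number here means more inhibition at the concentration tested (going by the name of the read-out), a lower number less inhibition), compound 1 gives 58%, the lower of the two numbers shown; compound 2 gives 94.1%, a gap beyond the scatter, though no single-point step between the two is listed.

Compound 3, `Cc1ccc(Nc2cc(NC(=O)Nc3c(Cl)cccc3Cl)ncn2)cc1C`, differs from compound 1 by 3,4-dimethylphenyl in place of 4-ethylphenyl on a nitrogen on an aromatic ring. Among the compounds with values here, the two compounds hold the same atoms, joined differently, and no measured step of this kind is available for guidance. A step of a number 4 percentage points higher from compound 1 to compound 3 (within the scatter) is expected from compound 1 to compound 3, small and likely within the scatter, with direction uncertain. Compound 3 is estimated at 62%, within 42% to 82%.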

Compound 3, a percentage reported as inhibition, at one concentration (the size of the read-out at that concentration, not a potency): 84.3%
The estimate for compound 3 lay 22.3 percentage points below the measured number; the measured number lies above the stated range.
By their numbers in this assay, from the lowest: compound 1; then compounds 3 and 2 (each within the scatter of the next).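

In this assay, 3,4-dimethylphenyl in place of 4-ethylphenyl gives a number 26.3 percentage points higher from compound 1 to compound 3 (beyond the scatter). The two groups have the same atoms, joined differently, so at this position on the nitrogen the read-out responds to how the aryl substituents are arranged, not only to which atoms are present. Nothing available explains this gain.

Going by these compounds, it remains open whether a phenyl carrying one methyl group would read like compound 1 or compound 3, and how a propyl chain or a morpholine ring would read here. These single-concentration numbers also leave potency unresolved.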